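The compounds below may be only part of what the source reports. "The series", "measured", "known", "first", "only" and "open" are said of these compounds alone.

Measured so far:
compound 1 `CC(=O)N1CCN(C2CN(CCC3(c4ccc(Cl)c(Cl)c4)CCC(=O)N(Cc4ccccc4)C3)C2)CC1` gives 1.59 nM
compound 2 `CS(=O)(=O)N1CCN(C2CN(CCC3(c4ccc(Cl)c(Cl)c4)CCC(=O)N(Cc4ccccc4)C3)C2)CC1` gives 0.631 nM
compound 3 `O=C1CCC(CCN2CC(N3CCC(O)C3)C2)(c2ccc(Cl)c(Cl)c2)CN1Cc1ccccc1` gives 2 nM

All three share one core and differ only in the group carried on a saturated ring carbon. In an assay on isolated protein (artery, Oryctolagus cuniculus) with Substance-P receptor (Homo sapiens) as the target (on this read-out higher numbers stand for weaker binding and lower numbers for tighter binding), compound 3 stands at the highest of the three numbers: compound 1 is its nearest neighbour, the difference being a 1.3-fold higher number from compound 1 to compound 3 (0.10 log units; within the scatter), while the step of a 3.2-fold higher number from compound 2 to compound 3 (0.50 log units; beyond the scatter) is the larger one. The change from compound 1 to compound 2, a 2.5-fold lower number from compound 1 to compound 2 (0.40 log units; beyond the scatter), shows that even a small alteration at this position can shift the number by a modest amount.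

Compound 4 `O=C1CCC(CCN2CC(N3CCCC(O)C3)C2)(c2ccc(Cl)c(Cl)c2)CN1Cc1ccccc1` is not yet measured. Its difference from compound 3 is 3-hydroxypiperidin-1-yl in place of 3-hydroxypyrrolidin-1-yl on a saturated ring carbon, the same five-membered ring with one hetero atom grown to a six-membered one. Going by the values given here, no measured step is of exactly this kind; the nearest guides are the swaps at the same ring carbon, a 1.3-fold higher number from compound 1 to compound 3 (0.10 log units; within the scatter) and a 3.2-fold higher number from compound 2 to compound 3 (0.50 log units; beyond the scatter), which were within the scatter or modest. The step of no change at the digits printed from compound 3 to compound 4 (within the scatter) is therefore expected to be small, with no confident direction. Compound 4 is estimated at 2 nM, with a range from 0.8 nM to 5 nM.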

Compound 4, dissociation constant: 2 nM
Compound 4: the middle estimate sits on the measured number at the digits printed; low and high end bracket the measured number.
By their numbers in this assay, from the lowest: compound 2; then compounds 1, 3 and 4 (each within the scatter of the next).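

In this assay, enlarging the five-membered ring of 3-hydroxypyrrolidin-1-yl to the six-membered ring of 3-hydroxypiperidin-1-yl on the four-membered ring gives no change at the digits printed from compound 3 to compound 4 (within the scatter), so this one change of ring size leaves no mark on the read-out. The new compound also sits where compound 3 sits relative to the two piperazine compounds: a 1.3-fold higher number from compound 1 to compound 4 (0.10 log units; within the scatter), while a 3.2-fold higher number from compound 2 to compound 4 (0.50 log units; beyond the scatter), which leaves compound 2 as the only one set apart from the rest. Nothing available here explains why ring size made no visible difference.

Both rings compared here carry a hydroxyl, so the compounds shown leave open whether plain piperidin-1-yl without that hydroxyl would read the same. They also leave open how morpholin-4-yl or a simple dimethylamino group would behave at this carbon.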